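The compounds below may be only part of what the source reports. "The series", "measured", "known", "first", "only" and "open" are said of these compounds alone.

Among the compounds with values here, in an ADME assay on MT4 cells (Homo sapiens) for cytotoxicity (a lower number here means that less compound is tolerated, a higher number that more compound is tolerated), only one compound has so far given a true number. Compound 1 `Cc1cc(C)cc(S(=O)(=O)n2c(SCC(=O)Nc3ccccc3[N+](=O)[O-])nc3ccc(Cl)cc32)c1` reads as a limit, > 235000 nM. Compound 2 `COC(=O)c1ccc(NC(=O)CSc2nc3ccc(Cl)cc3n2S(=O)(=O)c2cc(C)cc(C)c2)c(Cl)c1` also reads as a limit, >= 130000 nM. Within the data shown here, compound 3 `Cc1cc(C)cc(S(=O)(=O)n2c(SCC(=O)Nc3ccc(S(C)(=O)=O)cc3Cl)nc3ccc(Cl)cc32)c1` gives 3590 nM, the only number in the set and the lowest reading.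

Compound 4 `Cc1cc(C)cc(S(=O)(=O)n2c(SCC(=O)Nc3ccc(S(N)(=O)=O)cc3Cl)nc3ccc(Cl)cc32)c1` differs from compound 3 in a single place: amino in place of methyl on a sulfonyl sulfur. This change turns methylsulfonyl into sulfamoyl.

Among the measured compounds shown here, two measured steps bear on this change. Both are large: an at least 65-fold lower number from compound 1 to compound 3 (1.81 log units; beyond the scatter), and an at least 36-fold lower number from compound 2 to compound 3 (1.55 log units; beyond the scatter). The second falls on the same aromatic carbon, where methylsulfonyl replaces methoxycarbonyl. Neither step alters the group on the sulfonyl sulfur, so they show only that this assay can respond strongly to changes on this aryl group.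

A modest rise is therefore expected, and the expected step is a 3.3-fold higher number from compound 3 to compound 4 (0.52 log units; beyond the scatter). Compound 4 is estimated at 12000 nM, with an expected range of 2500 nM to 120000 nM.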

Compound 4, half-maximal cytotoxic concentration: 23400 nM
Compound 4: middle estimate off by 2.0-fold (0.29 log units), on the low side; low and high end bracket the measured number.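

Amino in place of methyl on a sulfonyl sulfur is the first change in this series made at that group itself, and in this assay it gives a 6.5-fold higher number from compound 3 to compound 4 (0.81 log units; beyond the scatter), so the group on the sulfur alone moves the reading. Compound 4 does not reach the two compounds that read as limits, with an at least 5.5-fold lower number from compound 2 to compound 4 (0.74 log units; beyond the scatter) and an at least 10-fold lower number from compound 1 to compound 4 (1.00 log units; beyond the scatter) still standing; both steps start from a limit of the assay and not from a number. No measured property among the compounds shown accounts for the rise.

As far as these compounds go, whether methylamino or dimethylamino on the sulfonyl sulfur would follow amino or follow methyl remains open. So does how a carboxylic acid on the same aromatic carbon would read in this assay.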